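A few compounds are considered here, and "the series" means these few. Any claim that something is new, unique, unknown or untested is made for them only; others in the source may bear on it.

Compound 1 `CCCCNC(=O)OCC(O)Cn1cc(CN(C)CCC(C)C)nn1` and compound 2 `CCCCNC(=O)OCC(O)Cn1cc(CN2CCN(c3ccccc3)CC2)nn1` share much of their structure but carry different cores; how the two cores differ is not broken down here. In an assay on nucleic acid for inhibition of Nucleic Acid, read by fluorescence, tested at 100 uM (a lower number here means less inhibition, a higher number more inhibition at the concentration tested (going by the name of the read-out)), compound 1 gives 24%, while compound 2 gives 11%. Compound 3 `CCCCC(O)Cn1cc(CN2CCN(c3ccccc3)CC2)nn1` differs from compound 2 in a single place (propyl in place of (butylcarbamoyl)oxy on a saturated chain carbon, two bonds along the chain from an oxygen on a saturated carbon), and with that change inhibition rises: compound 3 gives 47%, which is a number 36 percentage points higher from compound 2 to compound 3 (beyond the scatter). Compound 4 `CCCCC(O)Cn1cc(CN(C)CCC(C)C)nn1` carries the same kind of change on the core of compound 1 (propyl in place of (butylcarbamoyl)oxy on a saturated chain carbon, two bonds along the chain from an oxygen on a saturated carbon), and the place of the change is described in the same words for both pairs. Among the compounds with values here, because the one measured instance of this change gave a number 36 percentage points higher from compound 2 to compound 3 (beyond the scatter), a step of comparable size is expected, a number 31 percentage points higher from compound 1 to compound 4 (beyond the scatter), though it rests on a single pair. Compound 4 is therefore estimated at 55%, between 35% and 75%.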

Compound 4, a percentage reported as inhibition, at one concentration (the size of the read-out at that concentration, not a potency): 47%
Compound 4: middle estimate off by 8 percentage points, on the high side; low and high end bracket the measured number.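

In this assay, putting propyl in place of (butylcarbamoyl)oxy on the core of compound 1 gives a number 23 percentage points higher from compound 1 to compound 4 (beyond the scatter). Set beside the earlier pair, the change points the same way on both cores, and the two steps do not differ by more than repeat measurements would allow: the same change on two cores in this assay, a number 36 percentage points higher (beyond the scatter) from compound 2 to compound 3 and a number 23 percentage points higher (beyond the scatter) from compound 1 to compound 4, 13 percentage points apart, within the scatter of two such steps So the rise carries over between these two cores, but two cores cannot show that it holds across the series, and a reading at one concentration is not a potency.

The compounds shown leave open whether the rise comes from losing (butylcarbamoyl)oxy or from gaining propyl. A longer chain such as hexyl, or an amine, at the same place would help separate the two.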